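The source may report more compounds than this note shows. Statements on the series, on what has been measured and on what is new or still open speak of the compounds shown alone.

In a functional assay (Cavia porcellus) with sulfonylurea receptors; K-ATP channels (Homo sapiens) as the target (on this read-out higher numbers stand for weaker inhibition and lower numbers for stronger inhibition), compound 2 `Cc1cccc(S(=O)(=O)c2ccc(NC(=O)C(C)(O)C(F)(F)F)cc2)c1` gives 2200 nM, which stands lowest of the two numbers shown, although the gap to compound 1 `CC(O)(C(=O)Nc1ccc(S(=O)(=O)c2cccc(F)c2)cc1)C(F)(F)F`, which gives 3400 nM, is within the scatter. Compound 3 `CC(O)(C(=O)Nc1ccc(S(=O)(=O)c2cccc(C(F)(F)F)c2)cc1)C(F)(F)F` differs from compound 2 in one place: trifluoromethyl in place of methyl on an aromatic carbon. Among the compounds with values here, the only measured step at that position, a 1.5-fold lower number from compound 1 to compound 2 (0.19 log units; within the scatter), did not move the number beyond the scatter, so for compound 3 the expected step of no change at the digits printed from compound 2 to compound 3 (within the scatter) in this assay is also none beyond the scatter. Compound 3 is therefore estimated at 2200 nM, with a range from 800 nM to 6000 nM.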

Compound 3, half-maximal inhibitory concentration: > 30000 nM
Compound 3 ended at the assay's limit; the forecaster's own chance of this, stated with the estimate: 5%; at least 13-fold (1.13 log units) between middle value and limit.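

In this assay, this position turns out to be sensitive to which group sits on it: trifluoromethyl gives an at least 13-fold higher number from compound 2 to compound 3 (1.13 log units; beyond the scatter), and also an at least 8.8-fold higher number from compound 1 to compound 3 (0.94 log units; beyond the scatter). Compound 3 gives > 30000 nM, which is a limit of the assay and not a number. The swap between fluoro and methyl stayed within the scatter and gave no sign that a change here could matter this much. As far as these compounds go, whether a chloro, a methoxy or an amine in this place would stay close to compound 2 or also reach the limit remains open.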